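Phenoxybenzylidene thiosemicarbazides: lipophilicity notes, compound 4

The compounds below may be only part of what the source reports. "The series", "measured", "known", "first", "only" and "open" are said of these compounds alone.

Measured so far:
compound 1 `Fc1ccc(NC(=S)N/N=C/c2ccc(Oc3ccc(F)cc3)cc2)cc1` — 5.19
compound 2 `O=[N+]([O-])c1ccc(Oc2ccc(/C=N/NC(=S)Nc3ccc(Cl)cc3)cc2)cc1` — 5.52
compound 3 `Cc1cc(Oc2ccc(/C=N/NC(=S)Nc3ccc(Cl)cc3)cc2)ccc1Cl` — 6.59

In a physicochemical assay for lipophilicity, in phosphate buffer, measured as octanol-water partition, with a stated time of 24 h (on this read-out lower numbers stand for lower lipophilicity and higher numbers for higher lipophilicity), compound 3 stands highest of the three numbers; the nearest is compound 2, the furthest compound 1, and both gaps are beyond the scatter. For the measured compounds named here, the only single-point step among the measured compounds is a number 1.07 log units higher from compound 2 to compound 3 (beyond the scatter), a large rise when the 4-chloro-3-methylphenyl group replaces 4-nitrophenyl on the aryl-ether oxygen.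

Compound 4 `Fc1ccc(Oc2ccc(/C=N/NC(=S)Nc3ccc(Cl)cc3)cc2)cc1` has not yet been measured in this assay. It differs from compound 3 at that same oxygen: 4-fluorophenyl in place of 4-chloro-3-methylphenyl on an oxygen on an aromatic ring. Going by the values given here, the aryl-ether position is thus the one varied in the only recorded step, and that step was large. The new group is the same 4-fluorophenyl that compound 1 carries on its ether oxygen, while compound 4 keeps the 4-chlorophenyl anilide of compounds 2 and 3; compound 1 sits well below compound 3 on this read-out, and compound 4 is expected to land between those two values. A clear drop from compound 3 is therefore expected, a number 0.99 log units lower from compound 3 to compound 4 (beyond the scatter), beyond the scatter.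

For compound 4 the estimate in this assay is 5.6, with a range from 5.1 to 6.1.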

Compound 4, partition coefficient: 5.84
For compound 4 the middle estimate is 0.24 log units below the measured one; low and high end bracket the measured number.
By their numbers in this assay, from the lowest: compound 1; then compound 2; then compound 4; then compound 3.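

On the oxygen on an aromatic ring, three groups now stand on the same remainder in this assay, and 4-fluorophenyl gives the intermediate number, with a number 0.32 log units higher from compound 2 to compound 4 (beyond the scatter) on going from nitro to fluoro and a number 0.75 log units lower from compound 3 to compound 4 (beyond the scatter) on going from 4-chloro-3-methylphenyl to 4-fluorophenyl. The large earlier step at this position therefore divides into two modest steps, each beyond the scatter. For the compounds shown here, a second place can also be read for the first time, with a number 0.65 log units higher from compound 1 to compound 4 (beyond the scatter) when chloro replaces fluoro on an aromatic carbon while the 4-fluorophenyl on the oxygen stays the same, though no measurement at hand explains any of these steps.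

From the compounds shown here alone, the chloro-for-fluoro change rests on this single pair, so whether it gives a similar step with 4-chloro-3-methylphenyl or 4-nitrophenyl on the oxygen remains open. Also open, going by these compounds, is where the number would fall with a carboxylic acid, an amine or a longer alkyl chain on the phenyl ring attached to that oxygen, as the three groups in hand give no basis for placing any of these.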